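Pentan-3-yl for Cyclohexyl on the Ester Tail

This account rests on a few compounds, and the source may have more. Where it says the series, first, only, none or still open, it means among the compounds named here.

Compound 1 `C[C@@H](O)[C@H]1C(=O)N2C(C(=O)OCOC(=O)C3CCCCC3)=C(S[C@@H]3CN[C@H](C(=O)Nc4cccc(C(=O)O)c4)C3)[C@H](C)[C@H]12` was examined in an ADME assay for metabolic stability, read by LC-MS, with a stated time of 3 h, at pH 6.5, tested at 50 uM; on this read-out higher numbers stand for a more stable compound and lower numbers for a less stable compound; there compound 1 gives > 95%, which is a limit of the assay rather than a number. Compound 2 `CCOC(=O)C1=C(S[C@@H]2CN[C@H](C(=O)Nc3cccc(C(=O)OCC)c3)C2)[C@H](C)[C@@H]2[C@@H]([C@@H](C)OC(C)=O)C(=O)N12` likewise sits at a limit, since compound 2 gives > 95% in this assay. Compound 3 `CCOC(=O)C1=C(S[C@H]2C[C@@H](C(=O)Nc3cccc(C(=O)OCC)c3)N(C(=O)OCc3oc(=O)oc3C)C2)[C@H](C)[C@@H]2[C@@H]([C@@H](C)O)C(=O)N12` also reaches a limit, as compound 3 gives > 95% in this assay. Compound 1 therefore stands at the limit of > 95% in this assay, at which 3 of the 3 values shown sit. The unmeasured compound 4 `CCC(CC)C(=O)OCOC(=O)C1=C(S[C@@H]2CN[C@H](C(=O)Nc3cccc(C(=O)O)c3)C2)[C@H](C)[C@@H]2[C@@H]([C@@H](C)O)C(=O)N12` differs from compound 1 in a single place: pentan-3-yl in place of cyclohexyl on a carbonyl carbon. Within the data shown here, no step between measured compounds is available to set a size, and in this assay no change beyond the usual scatter is expected, so the estimated step is a number no higher from compound 1 to compound 4 (the limit leaves the size open). Compound 4 is accordingly expected to give 95%, within a range from 85% to 100%.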

Compound 4, percent of the compound remaining: > 95%
Compound 4 gave a limit, no number (the forecaster's own chance of this, stated with the estimate: 80%); the middle value lies on the limit itself.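

In this assay no step can be read between compound 1 and compound 4, whose values are both limits of the assay: the limit of > 95% in this assay, at which 4 of the 4 values shown sit.

The compounds shown leave open whether pentan-3-yl in place of cyclohexyl on a carbonyl carbon changes the result in this assay at all.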